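The source may report more compounds than this note shows. Statements on the series, on what has been measured and on what is new or still open speak of the compounds shown alone.

Measured compounds:
Compound 1, `COc1ccc2cc(C(C)c3nnc4n3N=C(c3ccc([N+](=O)[O-])cc3)CS4)ccc2c1`, in a functional assay on Huh-7 cells (Homo sapiens) for inhibition, read by sulforhodamine B assay, with a stated time of 72 h (on this read-out higher numbers stand for weaker inhibition and lower numbers for stronger inhibition), gives 14700 nM.
Compound 2, `COc1ccc2cc(C(C)c3nnc4n3N=C(c3ccc(C(F)(F)F)cc3)CS4)ccc2c1`, in this assay gives 14800 nM.
Compound 3, `CC(C)Cc1ccc(C(C)c2nnc3n2N=C(c2ccc([N+](=O)[O-])cc2)CS3)cc1`, in this assay is reported as "not active" (no number reported).

Compound 4, `CC(C)Cc1ccc(C(C)c2nnc3n2N=C(c2ccc(C(F)(F)F)cc2)CS3)cc1`, has not yet been measured. Among the measured compounds shown here, it carries the same change as the one between compound 1 and compound 2, which is trifluoromethyl in place of nitro on an aromatic carbon. That step gave a 1.0-fold higher number from compound 1 to compound 2 (0.00 log units; within the scatter). How the core of compound 3 differs from the core of compound 1 is not broken down here. The change from compound 3 to compound 4 is trifluoromethyl in place of nitro on an aromatic carbon, made at the same kind of place, so it is the same change. Since compound 1 and compound 2 are within scatter, the expectation is that compound 4 stays near the level of compound 3, which was reported as inactive. Compound 4 is therefore estimated at 40000 nM in this assay, between 15000 nM and 120000 nM, with a real chance that only a limit is reported.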

Compound 4, half-maximal inhibitory concentration: 8400 nM
For compound 4 the middle estimate is 4.8-fold (0.68 log units) above the measured one, outside the stated range (below it).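

Among the compounds shown here, compound 3 carries only the report "not active" and no number, so no step from compound 3 to compound 4 can be read. The compounds shown leave open how far compound 4 differs from compound 3, and no measurement shown offers an explanation.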